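A few compounds are considered here, and "the series" means these few. Any claim that something is new, unique, unknown or untested is made for them only; others in the source may bear on it.

In a functional assay on MCF7 cells (Homo sapiens) for cytotoxicity, read by neutral red uptake, with a stated time of 3 days (a lower number here means a stronger inhibitor, a higher number a weaker inhibitor), compound 1 `CCC(=O)OCc1c(F)c(N)c2c(=O)cc(-c3ccc(N)c(F)c3)oc2c1F` gives 130 nM, and compound 2 `CCCCCC(=O)OCc1c(F)c(N)c2c(=O)cc(-c3ccc(N)c(F)c3)oc2c1F` gives 160 nM. The change between them is propyl in place of hydrogen on a saturated chain carbon, two bonds along the chain from a carbonyl carbon, and it produced a 1.2-fold higher number from compound 1 to compound 2 (0.09 log units; within the scatter). Compound 3 `CCCOCc1c(F)c(N)c2c(=O)cc(-c3ccc(N)c(F)c3)oc2c1F` differs from compound 1 in its core: propyl in place of propanoyl on an oxygen on a saturated carbon. In this assay compound 3 gives 1200 nM, which is a 9.2-fold higher number from compound 1 to compound 3 (0.97 log units; beyond the scatter) and a 7.5-fold higher number from compound 2 to compound 3 (0.88 log units; beyond the scatter). Compound 4 `CCCCCCOCc1c(F)c(N)c2c(=O)cc(-c3ccc(N)c(F)c3)oc2c1F` is reached from compound 3 by propyl in place of hydrogen on a saturated chain carbon, three bonds along the chain from an oxygen on a saturated carbon, the same kind of change as that from compound 1 to compound 2, though here the place is three bonds along the chain from an oxygen on a saturated carbon rather than two bonds along the chain from a carbonyl carbon. Because the earlier step was a 1.2-fold higher number from compound 1 to compound 2 (0.09 log units; within the scatter), the step expected for compound 4 is a 1.2-fold higher number from compound 3 to compound 4 (0.07 log units; within the scatter). Compound 4 is therefore estimated at 1400 nM, expected to lie between 600 nM and 3500 nM.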

Compound 4, half-maximal inhibitory concentration: 7100 nM
Compound 4: middle estimate off by 5.1-fold (0.71 log units), on the low side; measured number outside the range, above it.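

The new step is a 5.9-fold higher number from compound 3 to compound 4 (0.77 log units; beyond the scatter), so in this assay propyl in place of hydrogen did not carry over unchanged from the core of compound 1 to the core of compound 3. Hexyl in place of pentylcarbonyl gives a 44-fold higher number from compound 2 to compound 4 (1.65 log units; beyond the scatter), and hexyl in place of propanoyl gives a 55-fold higher number from compound 1 to compound 4 (1.74 log units; beyond the scatter). These two cores show only that the size of the step differed between them, not how it would behave on a third core or why it differed: the same change on two cores in this assay, a 1.2-fold higher number (0.09 log units; within the scatter) from compound 1 to compound 2 and a 5.9-fold higher number (0.77 log units; beyond the scatter) from compound 3 to compound 4, 4.8-fold (0.68 log units) apart, beyond the scatter of two such steps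

The compounds shown leave open where a butyl or an octyl chain on the oxygen would fall. They also leave open whether a chain carrying an amine or a carboxylic acid would follow either step.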